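Trimming a methyl from the side chain of compound 2

The source may hold more compounds than are shown below. What is called first, only, known or untested is meant among the compounds shown, and "the series" means these compounds.

Compound 1: `CC(C)[C@H](N)C(=O)Nc1cc2cc[nH]c(=O)c2cc1Cl` — 12 nM
Compound 2: `CC(C)(C)C[C@@H](N)C(=O)Nc1cc2cc[nH]c(=O)c2cc1Cl` — 110 nM
Compound 3: `CN(C)[C@H]1CC[C@@H](C(=O)Nc2cc3cc[nH]c(=O)c3cc2Cl)CC1` — 1000 nM

In an assay on isolated protein for inhibition of Rho-associated protein kinase 2 (Homo sapiens) (on this read-out lower numbers stand for stronger inhibition and higher numbers for weaker inhibition), compound 2 stands second highest of the three numbers: compound 3 gives 1000 nM, a higher number, while compound 1 gives 12 nM, a lower one. Compound 4, `CC(C)C[C@@H](N)C(=O)Nc1cc2cc[nH]c(=O)c2cc1Cl`, has not yet been measured and differs from compound 2 by hydrogen in place of methyl on a saturated chain carbon bound to three saturated chain carbons; cut one bond further out this reads as tert-butyl to isopropyl, or 1-amino-3,3-dimethylbutyl to 1-amino-3-methylbutyl. Within the data shown here, the only measured step that bears on it is a 9.2-fold higher number from compound 1 to compound 2 (0.96 log units; beyond the scatter), where a 1-amino-3,3-dimethylbutyl group took the place of a 1-amino-2-methylpropyl group. Compound 4 undoes part of that growth, so the number is expected to fall back toward that of compound 1 without reaching it, a step of a 3.1-fold lower number from compound 2 to compound 4 (0.50 log units; beyond the scatter). Compound 4 is therefore estimated at 35 nM, with a range from 12 nM to 110 nM.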

Compound 4, half-maximal inhibitory concentration: 19 nM
Compound 4: middle estimate off by 1.8-fold (0.27 log units), on the high side; low and high end bracket the measured number.
By their numbers in this assay, from the lowest: compounds 1 and 4 (each within the scatter of the next); then compound 2; then compound 3.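

In this assay the one methyl that separates the tert-butyl end of compound 2 from the isopropyl end of compound 4 accounts for a 5.8-fold lower number from compound 2 to compound 4 (0.76 log units; beyond the scatter) and thus for most of the rise first seen with the 1-amino-3,3-dimethylbutyl group. Lengthening the side chain without that methyl, with 1-amino-3-methylbutyl in place of 1-amino-2-methylpropyl, gives a 1.6-fold higher number from compound 1 to compound 4 (0.20 log units; within the scatter) and so does not separate these two compounds. No evidence at hand explains why this one methyl matters so much.

The compounds shown leave open how a cyclopropyl or phenyl group in place of the isopropyl end would read in this assay. They also leave open whether an unbranched chain, or a hydroxyl or amine at its end, would behave like compound 4 or like compound 2.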